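Aryl variation at the chain carbon, compound 3 to 4

The source may report more compounds than this note shows. Statements on the series, on what has been measured and on what is new or still open speak of the compounds shown alone.

Three compounds share a core and differ only in the aryl group on a saturated chain carbon bound to an aromatic carbon and a nitrogen on an aromatic ring. In a functional assay on U-87MG ATCC cells for inhibition, with U-87 MG (Homo sapiens) as the target, read by MTT assay, with a stated time of 72 h (on this read-out higher numbers stand for weaker inhibition and lower numbers for stronger inhibition), compound 1 `Cc1cc(C)c(C(Nc2ccccn2)c2ccc3cccnc3c2O)c(C)c1` gives 10000 nM, compound 2 `Cc1ccc(C)c(C(Nc2ccccn2)c2ccc3cccnc3c2O)c1` gives 13800 nM, and compound 3 `COc1cccc(C(Nc2ccccn2)c2ccc3cccnc3c2O)c1` gives 11900 nM. Compound 3 stands second highest of the three numbers, with compound 2 nearest and compound 1 furthest, all within the scatter. Compound 4 `Oc1c(C(Nc2ccccn2)c2c(Cl)cccc2Cl)ccc2cccnc12` differs from compound 3 by 2,6-dichlorophenyl in place of 3-methoxyphenyl on a saturated chain carbon bound to an aromatic carbon and a nitrogen on an aromatic ring. For the measured compounds named here, the steps at this place so far, a 1.4-fold higher number from compound 1 to compound 2 (0.14 log units; within the scatter), a 1.2-fold higher number from compound 1 to compound 3 (0.08 log units; within the scatter) and a 1.2-fold lower number from compound 2 to compound 3 (0.06 log units; within the scatter), all stay within the scatter, so no step beyond the scatter is expected here either. Compound 4 is estimated at 12000 nM, range 5000 nM to 30000 nM, which means an expected step of a 1.0-fold higher number from compound 3 to compound 4 (0.00 log units; within the scatter).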

Compound 4, half-maximal inhibitory concentration: 6900 nM
Beside the measured number, compound 4's estimate is 1.7-fold (0.24 log units) above it; measured number inside the range.
By their numbers in this assay, from the lowest: compounds 4, 1, 3 and 2 (each within the scatter of the next).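

With 2,6-dichlorophenyl, chlorine now sits on the aryl group at the saturated chain carbon, and all three new steps stay within the scatter (a 1.7-fold lower number from compound 3 to compound 4 (0.24 log units; within the scatter)) and (a 2.0-fold lower number from compound 2 to compound 4 (0.30 log units; within the scatter)) and (a 1.4-fold lower number from compound 1 to compound 4 (0.16 log units; within the scatter)). Methyl, methoxy and chlorine on this phenyl group therefore give no step beyond the scatter across compounds 1 to 4. No measurement available here explains this flat read-out.

Going by these compounds, whether a carboxylic acid or an amine on the phenyl group, or cyclohexyl in its place, would move the number beyond the scatter remains open.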